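The source may hold more compounds than are shown below. What is called first, only, known or untested is meant among the compounds shown, and "the series" means these compounds.

Measured so far in a functional assay on A549 cells (Homo sapiens) for cytotoxicity, read by MTT assay, with a stated time of 48 h; on this read-out higher numbers stand for weaker inhibition and lower numbers for stronger inhibition:
Compound 1 `CCOC(=O)[C@]1(C(=O)Nc2ccccc2)C[C@@H]1c1cc(OC)c(OC)c(OC)c1` gives 21300 nM.
Compound 2 `COc1cc([C@H]2C[C@]2(CO)C(=O)Nc2ccccc2)cc(OC)c1OC` reaches only a limit of the assay, > 100000 nM.
Compound 3 `CCOC(=O)[C@@]1(C(=O)NCc2ccc(C)cc2)C[C@@H]1c1cc(OC)c(OC)c(OC)c1` likewise reaches only a limit of the assay, > 100000 nM.

The change from compound 1 to compound 2 is hydroxymethyl in place of ethoxycarbonyl on a saturated ring carbon, and it brought an at least 4.6-fold higher number from compound 1 to compound 2 (0.67 log units; beyond the scatter), a step that ends at a limit. How the core of compound 1 and the core of compound 3 differ is not broken down here. Compound 4 `COc1cc([C@H]2C[C@@]2(CO)C(=O)NCc2ccc(C)cc2)cc(OC)c1OC`, not yet measured, carries the same change relative to compound 3: hydroxymethyl in place of ethoxycarbonyl on a saturated ring carbon. Within the data shown here, because compound 3 already sits at the limit of > 100000 nM in this assay, at which 2 of the 3 values shown sit, no step can be seen as a number, and the expected step is a step that the limit leaves unreadable from compound 3 to compound 4. Compound 4 is therefore expected to give 150000 nM in this assay, most likely again only a limit.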

Compound 4, half-maximal inhibitory concentration: 63800 nM
Compound 4: the middle estimate sits 2.4-fold (0.37 log units) above what was measured, and the stated range ends above it.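

On the core of compound 3 in this assay, hydroxymethyl in place of ethoxycarbonyl on a saturated ring carbon brought an at least 1.5-fold lower number from compound 3 to compound 4 (0.19 log units; that floor lies within the scatter), and the same change did not behave alike on the two cores: the same change on two cores in this assay, an at least 4.6-fold higher number (0.67 log units; beyond the scatter) from compound 1 to compound 2 and an at least 1.5-fold lower number (0.19 log units; that floor lies within the scatter) from compound 3 to compound 4, at least 7.3-fold (0.86 log units) apart, beyond the scatter of two such steps

Compound 3 stands only at a limit of the assay, > 100000 nM. Each of the two steps has one end at a limit, so their true sizes stay unknown, and two cores neither give a rule for the series nor show why the steps part.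

The compounds shown leave open how a carboxylic acid or an amine on that saturated ring carbon would read on either core. Also open, from the compounds shown here alone, is whether a core with a longer chain on the amide would follow compound 2 or compound 4.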